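Aryl hydroxy in place of methyl on the pyrrolidine series

A few compounds are considered here, and "the series" means these few. Any claim that something is new, unique, unknown or untested is made for them only; others in the source may bear on it.

Compound 1 `Cc1ccc([C@]2(CO)NC[C@@H](O)[C@@H]2O)cc1` is the weakest of the three measured here: in an assay on isolated protein for inhibition of lysosomal alpha-glucosidase (Rattus norvegicus), read by colorimetric assay (a higher number here means a weaker inhibitor, a lower number a stronger inhibitor), compound 1 gives 43000 nM, the highest number in the set. For the measured compounds named here, its mirror image, compound 3 `Cc1ccc([C@@]2(CO)NC[C@H](O)[C@H]2O)cc1`, gives 17000 nM, and the step of a 2.5-fold lower number from compound 1 to compound 3 (0.40 log units; beyond the scatter) is the only one-point change measured so far; it rests on (the fact that compounds 1 and 3 differ only in the configuration as drawn). The butyl analogue, compound 2 `CCCC[C@]1(CO)NC[C@@H](O)[C@@H]1O`, gives 16000 nM, which sits close to compound 3.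

Compound 4 `OC[C@@]1(c2ccc(O)cc2)NC[C@@H](O)[C@@H]1O` is compound 1 with hydroxy in place of methyl on an aromatic carbon. Going by the values given here, no measured step in this set changes a substituent on the aromatic ring; the single measured step concerns configuration only and so says nothing about this exchange. The expectation for compound 4 is therefore anchored on compound 1 at 43000 nM, with no direction assigned beyond the scatter. For compound 4 the estimate in this assay is 30000 nM, between 8000 nM and 120000 nM. This estimate corresponds to an expected step of a 1.4-fold lower number from compound 1 to compound 4 (0.16 log units; within the scatter).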

Compound 4, half-maximal inhibitory concentration: 11000 nM
The estimate for compound 4 lay 2.7-fold (0.44 log units) above the measured number; the range from low to high includes it.
By their numbers in this assay, from the lowest: compounds 4, 2 and 3 (each within the scatter of the next); then compound 1.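

Working notes on the aromatic position: in this assay, hydroxy in place of methyl on an aromatic carbon gives a 3.9-fold lower number from compound 1 to compound 4 (0.59 log units; beyond the scatter), the first measured sign that the number responds to a substituent at this place on the ring. For the compounds shown here, the only earlier step, a 2.5-fold lower number from compound 1 to compound 3 (0.40 log units; beyond the scatter), concerned configuration alone and could not show this. Nothing at hand bears on why this exchange lowers the number.

On these data alone, it remains open whether the step belongs to hydroxy itself or to the loss of methyl, which a comparison with methoxy, an amine or a carboxylic acid on the same aromatic carbon would help to separate. As far as these compounds go, it is also open whether the same exchange would give a similar step on the mirror-image configuration of compound 3.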